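Shortening the Ether Tail: From Sulfone to Methoxy

The compounds below may be only part of what the source reports. "The series", "measured", "known", "first", "only" and "open" are said of these compounds alone.

Measured compounds:
compound 1, `COc1ccc2c(c1)OC(COc1ccc(CCC(=O)O)c(F)c1)CC2`: 58%
compound 2, `CS(=O)(=O)CCCOc1ccc2c(c1)OC(COc1ccc(CCC(=O)O)c(F)c1)CC2`: 38%

In a functional assay on HEK293 cells for agonist activity at Free fatty acid receptor 1 (Homo sapiens), read by fluorescence and calcium flux, with a stated time of 10 min (a higher number here means a larger maximal response, a lower number a smaller maximal response), compound 1 gives 58%, while compound 2 gives 38%, the lower of the two numbers. Compound 3, `COCCOc1ccc2c(c1)OC(COc1ccc(CCC(=O)O)c(F)c1)CC2`, differs from compound 2 by methoxy in place of (methylsulfonyl)methyl on a saturated chain carbon, two bonds along the chain from an oxygen on an aromatic ring. Among the measured compounds shown here, the only step that bears on this change is a number 20 percentage points lower from compound 1 to compound 2 (beyond the scatter), where 2-(methylsulfonyl)ethyl in place of hydrogen went with a lower maximal response. Compound 3 carries a shorter tail without the sulfur group, partway back toward compound 1, so a partial recovery is expected, a step of a number 10 percentage points higher from compound 2 to compound 3 (within the scatter). Compound 3 is therefore estimated at 48%, between 35% and 62%.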

Compound 3, largest response reached (Emax), in percent of the reference or control that the assay uses: 36%
Beside the measured number, compound 3's estimate is 12 percentage points above it; low and high end bracket the measured number.
By their numbers in this assay, from the lowest: compounds 3 and 2 (each within the scatter of the next); then compound 1.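

In this assay, methoxy in place of (methylsulfonyl)methyl gives a number 2 percentage points lower from compound 2 to compound 3 (within the scatter), so the 3-(methylsulfonyl)propoxy and 2-methoxyethoxy tails cannot be told apart here. Methoxymethyl in place of hydrogen gives a number 22 percentage points lower from compound 1 to compound 3 (beyond the scatter), which shows that the lower maximal response also occurs with no sulfur in the tail. No measurement at hand explains this result.

Still open, as far as these compounds go, is whether a tail ending in an amine or a carboxylic acid would match compound 1 or compound 3, and how a plain ethoxy group or a longer chain would read.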